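Adding an Amino Group to a Benzyl-Purine Pair

The source may hold more compounds than are shown below. What is called first, only, known or untested is meant among the compounds shown, and "the series" means these compounds.

Compound 1, `ClCc1ccc(Cn2cnc3c(Cl)ncnc32)cc1`, is the strongest growth inhibitor among the three measured compounds: in a functional assay on 786-0 cells (Homo sapiens) for cytotoxicity, read by sulforhodamine B assay, with a stated time of 48 h (a lower number here means a stronger inhibitor of growth, a higher number a weaker inhibitor of growth), compound 1 gives 3980 nM. Compound 2, `Nc1nc(Cl)c2ncn(Cc3ccc(CCl)cc3)c2n1`, carries one change on the shared core, (amino in place of hydrogen on an aromatic carbon), and in this assay compound 2 gives 93300 nM, so the change made a 23-fold higher number from compound 1 to compound 2 (1.37 log units; beyond the scatter).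

Compound 3, `ClCc1ccccc1Cn1cnc2c(Cl)ncnc21`, is built from the same atoms as compound 1 joined differently; how the two cores differ is not broken down here. In this assay compound 3 gives 38000 nM.

Compound 4, `Nc1nc(Cl)c2ncn(Cc3ccccc3CCl)c2n1`, has not yet been measured. It differs from compound 3 by amino in place of hydrogen on an aromatic carbon, the same change in the same place as that from compound 1 to compound 2. Because that earlier change made a 23-fold higher number from compound 1 to compound 2 (1.37 log units; beyond the scatter), a step of similar size is expected for compound 4, namely a 7.9-fold higher number from compound 3 to compound 4 (0.90 log units; beyond the scatter). Compound 4 is therefore expected to give about 300000 nM in this assay, most likely somewhere from 60000 nM to 1000000 nM, with a real chance that only a limit is reported.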

Compound 4, concentration for total growth inhibition: 52500 nM
Beside the measured number, compound 4's estimate is 5.7-fold (0.76 log units) above it, outside the stated range (below it).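

In this assay, amino in place of hydrogen on an aromatic carbon gives a 1.4-fold higher number from compound 3 to compound 4 (0.14 log units; within the scatter), so on this core the change has no effect that can be told apart from repeat measurements. The same change therefore does not carry its size over from one core to the other: the same change on two cores in this assay, a 23-fold higher number (1.37 log units; beyond the scatter) from compound 1 to compound 2 and a 1.4-fold higher number (0.14 log units; within the scatter) from compound 3 to compound 4, 17-fold (1.23 log units) apart, beyond the scatter of two such steps. This shows that, for these two pairs, a step seen on one core is a poor guide to the step on the other, but it does not show why the cores respond differently, and two pairs give no rule for any further core.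

The compounds shown leave open how other groups at this place, such as a methylamine or a hydroxyl group, would behave on each core, and whether they too would give steps of different size. They also leave open whether a third core would follow compound 1 and compound 2 or compound 3 and compound 4.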